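The compounds below may be only part of what the source reports. "The series", "measured", "known", "first", "only" and "open" are said of these compounds alone.

Measured so far in a functional assay on the whole organism (strain Sprague-Dawley) for inhibition, with Rattus norvegicus as the target; a lower number here means that less compound is needed, a higher number that more compound is needed for the effect:
- compound 1, `Fc1ccc2ncc(-c3nn[nH]n3)cc2c1`: compound 1 gives < 25 mg/kg, which is a limit of the assay and not a number.
- compound 2, `O=c1c(-c2nn[nH]n2)c[nH]c2c(Cl)c(Cl)ccc12`: compound 2 gives > 0.156 mg/kg, likewise a limit rather than a number.
- compound 3, `Fc1cc(F)c2ncc(-c3nn[nH]n3)cc2c1`: compound 3 gives 10 mg/kg.

Among the compounds with values here, compound 3 therefore stands as the only compound with a read number in this assay; the other two values are limits. Within the data shown here, the single step between measured compounds that differ in one place, a step that the limit leaves unreadable from compound 1 to compound 3, cannot be sized, because the limit of < 25 mg/kg in this assay, at which 1 of the 3 values shown sits, leaves one end of it open.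

Compound 4, `Fc1cccc2cc(-c3nn[nH]n3)cnc12`, is reached from compound 3 by hydrogen in place of fluoro on an aromatic carbon. Among the measured compounds shown here, no measured step reports what the removal of a fluoro does here: the only one-point step in the set is unreadable, and compound 2 sits on a different core and at a limit. Nothing in the data supports a directional expectation beyond the scatter.

Compound 4 is accordingly expected near compound 3, at an estimated 15 mg/kg, with a range of 5 mg/kg to 50 mg/kg. The expected step is a 1.5-fold higher number from compound 3 to compound 4 (0.18 log units; within the scatter), that is, within the scatter of repeated measurements.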

Compound 4, minimum effective dose: > 10 mg/kg
Compound 4 ended at the assay's limit (the forecaster's own chance of this, stated with the estimate: 30%); the middle value is on the limit's open side.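

The change of fluoro to hydrogen on this aromatic carbon, meta to a fluoro group and para to a fused ring, is the only one-place step among those shown with a readable direction: in this assay it gives a number no lower from compound 3 to compound 4 (the limit leaves the size open). Compound 4 gives > 10 mg/kg, which is a limit of the assay and not a number. At this position, then, hydrogen brings no lower number than the fluoro of compound 3, a direction that the earlier one-place step, on a different fluoro, could not give.

Within the data shown here, the size of both one-place steps cannot be read, so how much of a loss, if any, follows from removing this fluoro remains open, and compound 3 still holds the only read number. Also open, as far as these compounds go, is how a methoxy group, an amine or a nitrile on this same aromatic carbon would compare with the fluoro of compound 3.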